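Chain length at the aryl ether: compound 3 to compound 4

A few compounds are considered here, and "the series" means these few. Any claim that something is new, unique, unknown or untested is made for them only; others in the source may bear on it.

Compound 1 `CCc1nncn1-c1ccc(OCc2ccccc2)cc1` gives 20.8 mg/kg in a functional assay on the whole organism (strain C57B/6) with Mus musculus as the target, in the maximal electroshock model (a lower number here means that less compound is needed, a higher number that more compound is needed for the effect), and compound 2 `CCc1nncn1-c1ccc(OCc2ccc(C)cc2)cc1` gives 25.5 mg/kg. Compound 3 `CCCOc1ccc(-n2cnnc2CC)cc1` returns only a limit, > 100 mg/kg, so it stands only as the limit of > 100 mg/kg in this assay, at which 1 of the 3 values shown sits, rather than as a number. The steps of an at least 4.8-fold higher number from compound 1 to compound 3 (0.68 log units; beyond the scatter) and an at least 3.9-fold higher number from compound 2 to compound 3 (0.59 log units; beyond the scatter) both run beyond the scatter in the same direction. Compound 4 `CCCCCCCOc1ccc(-n2cnnc2CC)cc1` differs from compound 3 by butyl in place of hydrogen on a saturated chain carbon, three bonds along the chain from an oxygen on an aromatic ring. Among the compounds with values here, no measured step bears directly on lengthening this chain; the two steps that reach compound 3 concern a ring in place of ethyl, not added chain carbons. Compound 4 is therefore estimated near 100 mg/kg, within 40 mg/kg to 300 mg/kg, expected as a step of a number no higher from compound 3 to compound 4 (the limit leaves the size open) in this assay, with a fair chance that only a limit is reported again.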

Compound 4, dose for half-maximal effect: 8.3 mg/kg
Estimate against measurement, compound 4: 12-fold (1.08 log units) above, outside the stated range (below it).
By their numbers in this assay, from the lowest: compound 4; then compounds 1 and 2 (each within the scatter of the next). At a limit, above all of these: compound 3.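

Butyl in place of hydrogen on this saturated chain carbon, turning propyl into heptyl, gives an at least 12-fold lower number from compound 3 to compound 4 (1.08 log units; beyond the scatter) in this assay, so chain length at this oxygen decides whether a number is reached at all. An aromatic ring at the chain end is not required for this effect, as hexyl in place of that ring gives a 2.5-fold lower number from compound 1 to compound 4 (0.40 log units; beyond the scatter) and a 3.1-fold lower number from compound 2 to compound 4 (0.49 log units; beyond the scatter). The size of the first step stays open-ended, as compound 3 is only a limit: the limit of > 100 mg/kg in this assay, at which 1 of the 4 values shown sits.

Where between propyl and heptyl the number first appears remains open, as does whether a longer chain such as decyl lowers it further. Also open, from the compounds shown here alone, is how an amine at the chain end would read in this assay.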